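Three Amide Variations on One Acid Core

The source may hold more compounds than are shown below. What is called first, only, known or untested is meant among the compounds shown, and "the series" means these compounds.

Compound 1 `COc1cc2c(cc1OC)C(CC(=O)O)CC2` was tested in a functional assay on the whole organism (strain Wistar) for inhibition, with Rattus norvegicus as the target, read by paw edema, with stated times of 60 min and 6 h, at a dose of 100 mg/kg by the oral route (a lower number here means less inhibition, a higher number more inhibition at the dose given (going by the name of the read-out)), where compound 1 gives 20.4%. For the measured compounds named here, of the three compounds measured so far, compound 1 sits lowest. Compound 2 `CNC(=O)CC1CCc2cc(OC)c(OC)cc21` gives 24.1%, and compound 3 `COc1cc2c(cc1OC)C(CC(=O)NC(C)(C)C)CC2` gives 31.5%. The step of a number 3.7 percentage points higher from compound 1 to compound 2 (within the scatter) stays within the scatter, whereas a number 11.1 percentage points higher from compound 1 to compound 3 (beyond the scatter) reaches beyond it; between the two amides themselves, a number 7.4 percentage points higher from compound 2 to compound 3 (within the scatter) falls within the scatter again.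

Compound 4 `COc1cc2c(cc1OC)C(CC(=O)NCCO)CC2` has not yet been measured. Its difference from compound 1 is (2-hydroxyethyl)amino in place of hydroxy on a carbonyl carbon. The measured steps that bear on this change are the two that likewise exchange the hydroxy on the carbonyl carbon for an amino group: a small one, from compound 1 to compound 2, and a modest one, from compound 1 to compound 3. Both run upward, the smaller amine giving the smaller rise. For compound 4 the expected step is therefore a number 5.6 percentage points higher from compound 1 to compound 4 (within the scatter), upward but not certainly beyond the scatter. The estimate for compound 4 is 26%, expected to fall between 14% and 38%.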

Compound 4, a percentage reported as inhibition, in the whole organism at one dose (the size of the read-out at that dose, not a potency): 13%
The estimate for compound 4 lay 13 percentage points above the measured number; measured number outside the range, below it.
By their numbers in this assay, from the lowest: compounds 4, 1, 2 and 3 (each within the scatter of the next, the first and the last beyond it).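

In this assay, the step of a number 7.4 percentage points lower from compound 1 to compound 4 (within the scatter) shows that exchanging the hydroxy on the carbonyl carbon for an amino group does not by itself set an amide apart from compound 1, and that a (2-hydroxyethyl)amino group leaves the number within the scatter of the acid. For the compounds shown here, the group on the amide-type nitrogen matters more than the earlier compounds could show: the step of a number 18.5 percentage points lower from compound 3 to compound 4 (beyond the scatter) for 2-hydroxyethyl in place of tert-butyl is beyond the scatter, and so is the step of a number 11.1 percentage points lower from compound 2 to compound 4 (beyond the scatter) for the smaller change of hydroxymethyl in place of hydrogen on a saturated chain carbon bound to that nitrogen. No measurement shown here gives a reason for these differences.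

The compounds shown leave open whether the lower number of compound 4 goes with its terminal hydroxy or with the length of its chain, a question an ethylamino or a 2-methoxyethylamino group on the same carbonyl carbon would address. They also leave open whether a group as large as tert-butyl but of another shape, such as a cyclohexylamino group, would match compound 3.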